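This account rests on a few compounds, and the source may have more. Where it says the series, first, only, none or still open, it means among the compounds named here.

Values measured in a functional assay on HCT-8 cells (Homo sapiens) for antiproliferative activity, read by MTT assay, with a stated time of 48 h (a lower number here means a stronger inhibitor, a higher number a weaker inhibitor), are as follows:
- compound 1 `COc1ccc(C(=O)c2ccc(OC)c3c2OC(C)(C)C=C3)c(NC(=O)CBr)c1` gives 3250 nM
- compound 2 `COc1ccc(C(=O)c2ccc(OC)c3c2C=CC(C)(C)O3)c(NC(=O)CBr)c1` gives 4360 nM
- compound 3 `COc1ccc(C(=O)c2ccc3c(c2)C=CC(C)(C)O3)c(NC(=O)CBr)c1` gives 3260 nM

Compound 1 stands within the scatter of both compound 2 and compound 3, so the three cannot be told apart on these numbers. Compound 4 `COc1ccc(C(=O)c2ccc(OC)c3c2OC(C)(C)C=C3)c(NC(=O)CO)c1` has not yet been measured in this assay and keeps the core of compound 1. Within the data shown here, the one change is hydroxy in place of bromo on a saturated chain carbon bound to a carbonyl carbon. Among the measured compounds shown here, all three measured compounds carry the bromo, and no measured pair differs in one place, so the data give no direct guide to this change. With compound 1 at 3250 nM as the closest anchor, no step beyond the scatter is expected, and neither direction is favoured with any confidence. The estimated step (a 1.2-fold higher number from compound 1 to compound 4 (0.09 log units; within the scatter)) is therefore small, though the uncertainty is wide. For compound 4 the estimated value is 4000 nM with an expected range from 600 nM to 20000 nM in this measurement.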

Compound 4, half-maximal inhibitory concentration: 230 nM
The estimate for compound 4 lay 17-fold (1.24 log units) above the measured number; measured number below the stated range.
By their numbers in this assay, from the lowest: compound 4; then compounds 1, 3 and 2 (each within the scatter of the next).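

In this assay, hydroxy in place of bromo on a saturated chain carbon bound to a carbonyl carbon gives a 14-fold lower number from compound 1 to compound 4 (1.15 log units; beyond the scatter) and is the only step shown so far. All three earlier compounds carry the bromo, so they could not show that this position affects the read-out; compound 4 shows that it does, and that the bromo is not needed for activity on the core of compound 1. No measurement shown here explains the step.

Whether this gain is specific to hydroxy remains open, as the compounds shown do not include an amine, a methoxy group or a longer hydroxyalkyl chain at this place. They also leave open whether the same change would have a similar effect on the cores of compound 2 and compound 3.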